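A few compounds are considered here, and "the series" means these few. Any claim that something is new, unique, unknown or untested is made for them only; others in the source may bear on it.

In an assay on HEK-293T cells for displacement of a labelled ligand from corticotropin-releasing factor receptor 2 (Homo sapiens), read by scintillation counting, with a stated time of 2 h, tested at 1 uM (on this read-out lower numbers stand for less inhibition and higher numbers for more inhibition at the one concentration tested (going by the name of the read-out)), the measured compounds stand as follows:
compound 1, `CCCCN(CC)c1cc(C)nc2c1NC(=O)CN2c1ccc(C(C)(C)C)cc1Br`, gives -3.8%;
compound 2, `CCCCN(CC)c1cc(C)nc2c1NC(=O)CN2c1ccc(Br)cc1Cl`, gives "not determined" (no result reported);
compound 3, `CCCCN(CC)c1cc(C)nc2c1NC(=O)CN2c1ccc(Br)cc1Br`, gives 9.4%.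

Compound 2 therefore has no number of its own in this assay, so its place among the others cannot be told. Compound 4, `CCCCN(CC)c1cc(C)nc2c1NC(=O)CN2c1ccc(Cl)cc1Cl`, differs from it by chloro in place of bromo on an aromatic carbon. Going by the values given here, the only measured step, a number 13.2 percentage points higher from compound 1 to compound 3 (beyond the scatter), concerns a different group at that position and bears on the present change only loosely; no measured pair exchanges bromo for chloro. Both measured values lie near zero, so compound 4 is expected to give a step no larger than the scatter. Its inhibition is estimated at 3%, within -12% to 18%.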

Compound 4, a percentage reported as inhibition, at one concentration (the size of the read-out at that concentration, not a potency): 0.9%
Beside the measured number, compound 4's estimate is 2.1 percentage points above it, within the range that was stated.
By their numbers in this assay, from the lowest: compounds 1, 4 and 3 (each within the scatter of the next, the first and the last beyond it).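

In this assay, replacing 2,4-dibromophenyl with 2,4-dichlorophenyl gives a number 8.5 percentage points lower from compound 3 to compound 4 (within the scatter), so exchanging both halogens together does not move the read-out beyond the scatter. Going by these compounds alone, compound 2 has no number, so the single change from 4-bromo-2-chlorophenyl to 2,4-dichlorophenyl cannot be read. No evidence is available to explain this result.

As far as these compounds go, it remains open how each halogen contributes separately. From the compounds shown here alone, it also remains open whether a methoxy group, a nitrile or an amine in place of the chloro para to a large group would change the inhibition.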